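Hydroxy for 2-(ethoxycarbonyl)ethenyl: compound 3 to compound 4

This account rests on a few compounds, and the source may have more. Where it says the series, first, only, none or still open, it means among the compounds named here.

In a functional assay on CLL cells (Homo sapiens) for cytotoxicity, read by MTT assay, with a stated time of 48 h (a higher number here means that more compound is needed for the effect, a lower number that less compound is needed), compound 1 `C=C(CC)C(=O)c1ccc(OCC(=O)Nc2nc3ccccc3s2)c(Cl)c1Cl` gives 1500 nM and compound 3 `C=C(CC)C(=O)c1ccc(OCC(=O)Nc2ccc(/C=C/C(=O)OCC)cc2)c(Cl)c1Cl` gives 1700 nM, two values within the scatter of each other. Compound 2 `C=C(CC)C(=O)c1ccc(OCC(=O)Nc2cccc(C(=O)O)c2)c(Cl)c1Cl` gives 20600 nM, a clearly higher number than either.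

Compound 4 `C=C(CC)C(=O)c1ccc(OCC(=O)Nc2ccc(O)cc2)c(Cl)c1Cl` is still unmeasured. It differs from compound 3 by hydroxy in place of 2-(ethoxycarbonyl)ethenyl on an aromatic carbon, para to a large group.

For the measured compounds named here, only one measured step bears on this, and only indirectly: a 14-fold higher number from compound 1 to compound 2 (1.14 log units; beyond the scatter), with 3-carboxyphenyl in place of 1,3-benzothiazol-2-yl on an amide-type nitrogen. It shows that a change in the group carried by that nitrogen can move this assay by a large amount. Going by the values given here, no measured compound carries a hydroxy group, so the direction is poorly supported. A moderate rise, smaller than that step, is expected.

The expected step is a 2.4-fold higher number from compound 3 to compound 4 (0.37 log units; beyond the scatter). For compound 4 the estimated value is 4000 nM, with an expected range from 1300 nM to 13000 nM.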

Compound 4, half-maximal effective concentration: 6400 nM
Compound 4: the middle estimate sits 1.6-fold (0.20 log units) below what was measured; low and high end bracket the measured number.
By their numbers in this assay, from the lowest: compounds 1 and 3 (each within the scatter of the next); then compound 4; then compound 2.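

In this assay, for the compounds shown here, hydroxy in place of 2-(ethoxycarbonyl)ethenyl gives a 3.8-fold higher number from compound 3 to compound 4 (0.58 log units; beyond the scatter), the first measured change on this aromatic carbon, para to a large group, and it lies beyond the scatter. On the amide-type nitrogen, 4-hydroxyphenyl is separated from both earlier extremes, with a 4.3-fold higher number from compound 1 to compound 4 (0.63 log units; beyond the scatter) against 1,3-benzothiazol-2-yl and a 3.2-fold lower number from compound 2 to compound 4 (0.51 log units; beyond the scatter) against 3-carboxyphenyl, so compound 4 takes an intermediate place in the series rather than matching either group. No measurement available here explains these steps.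

The change from compound 3 to compound 4 removes a chain of 7 heavy atoms and adds a hydrogen-bond donor at once, leaving the contribution of each unresolved. An amine, a methoxy group or a carboxylic acid on this same aromatic carbon would help to separate them.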